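Ester to Cyclopropyl Amide on a Shared Pyridine Acrylate Core

The source may hold more compounds than are shown below. What is called first, only, known or untested is meant among the compounds shown, and "the series" means these compounds.

Of the compounds shown here, three built on the same core have been measured in a functional assay on A549 cells (Homo sapiens) for inhibition, read by sulforhodamine B assay, with a stated time of 72 h; a higher number here means a weaker inhibitor of growth, a lower number a stronger inhibitor of growth. Compound 1 `CCOC(=O)/C=C/c1ccncc1-c1ccc2[nH]ccc2c1` gives 7440 nM. Compound 2 `CCOC(=O)/C=C/c1ccncc1-c1ccc2ccccc2c1` gives 5380 nM, the lowest of the three numbers, though both others lie within the scatter of it. Compound 3 `CNC(=O)/C=C/c1ccncc1-c1ccc2c(ccn2C)c1`, which carries a methyl amide in place of the ethyl ester, gives 6450 nM.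

The step considered here leads from compound 2 to compound 4 `O=C(/C=C/c1ccncc1-c1ccc2ccccc2c1)NC1CC1`, which is not yet measured. The change is cyclopropylamino in place of ethoxy on a carbonyl carbon.

Among the compounds with values here, no measured pair differs in one place, so no step size is known for this change. Within the data shown here, the only hint is that compound 3 with its amide gives 6450 nM and compound 1 with its ester gives 7440 nM, two numbers close to one another. On that basis the step in this assay from compound 2 to compound 4 is expected to be a 1.0-fold higher number from compound 2 to compound 4 (0.01 log units; within the scatter), within the scatter. Compound 4 is therefore expected to give about 5500 nM, estimated to fall between 2500 nM and 12000 nM.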

Compound 4, concentration for 50% growth inhibition: 5840 nM
Compound 4: middle estimate off by 1.1-fold (0.03 log units), on the low side, and the stated range covers the measured number.
By their numbers in this assay, from the lowest: compounds 2, 4, 3 and 1 (each within the scatter of the next).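

In this assay, within the data shown here, compound 2 and compound 4 form the first pair that differs in one place, and their step (a 1.1-fold higher number from compound 2 to compound 4 (0.04 log units; within the scatter)) lies within the scatter. On this carbonyl carbon and this core, cyclopropylamino in place of ethoxy therefore brings in a three-membered ring and a hydrogen-bond donor without a change beyond the scatter. The earlier compounds shown here could only hint at this. None of them formed such a pair. The data offer no independent measurement that would explain this result.

Going by these compounds, it remains open whether a carboxylic acid or a dimethylamino group in place of ethoxy on a carbonyl carbon would also stay within the scatter. On these data alone, it is also open whether the same exchange would give a similar step on compound 1.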